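A Benzyl Group Replaces a Phenoxy Group

The source may report more compounds than this note shows. Statements on the series, on what has been measured and on what is new or still open speak of the compounds shown alone.

Compound 1 `CC(C)=CCc1cc(C(=O)Nc2cc3ccc(Oc4ccc(C(C)(C)C)cc4)c(C)c3oc2=O)ccc1O`: 20600 nM
Compound 2 `COc1ccc(Cc2ccc3cc(NC(=O)c4ccc(OC(C)=O)c(CC=C(C)C)c4)c(=O)oc3c2C)cc1`: 11500 nM

In a functional assay on MCF7 cells (Homo sapiens) for antiproliferative activity (on this read-out lower numbers stand for stronger inhibition and higher numbers for weaker inhibition), compound 1 gives 20600 nM and compound 2 gives 11500 nM. For the measured compounds named here, these two values lie within the usual scatter of repeated measurements, so compound 1 stands level with the only other compound measured, and the numbers do not rank the pair.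

The next compound is compound 3 `COc1cc(Cc2ccc3cc(NC(=O)c4ccc(O)c(CC=C(C)C)c4)c(=O)oc3c2C)ccc1O`, which has not yet been measured. Going from compound 1 to compound 3, 4-hydroxy-3-methoxybenzyl takes the place of 4-(tert-butyl)phenoxy on an aromatic carbon of the core, ortho to a methyl group (4-hydroxy-3-methoxybenzyl in place of 4-(tert-butyl)phenoxy on an aromatic carbon). Going by the values given here, no measured pair shows this swap on its own, so any forecast is uncertain. Compound 2 also carries a benzyl group at this place, and its value of 11500 nM gives the main guide. On that basis, no change beyond the scatter is expected in this assay, and the estimated step is a 1.9-fold lower number from compound 1 to compound 3 (0.27 log units; within the scatter). For compound 3 the estimated value is 11000 nM, with an expected range from 3500 nM to 30000 nM.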

Compound 3, half-maximal inhibitory concentration: 14600 nM
Compound 3: the middle estimate sits 1.3-fold (0.12 log units) below what was measured; the range from low to high includes it.
By their numbers in this assay, from the lowest: compounds 2, 3 and 1 (each within the scatter of the next).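

For the compounds shown here, compounds 1 and 3 differ in one place only, so they give the first clean comparison at this aromatic carbon of the core, ortho to a methyl group: in this assay, 4-hydroxy-3-methoxybenzyl in place of 4-(tert-butyl)phenoxy gives a 1.4-fold lower number from compound 1 to compound 3 (0.15 log units; within the scatter). The entering group carries a hydrogen-bond donor and one more hydrogen-bond acceptor than the group it replaces and has no tert-butyl, yet this pair cannot be told apart on this read-out, so here the swap leaves the antiproliferative number unchanged within the usual scatter. No measurement at hand offers an explanation for this result.

This single swap alters the group's link to the core and the substituents on its ring together, so the pair cannot show whether either change alone would matter, or whether the two happen to offset each other. As far as these compounds go, it also remains open whether a quite different group at this place, such as an amine, a carboxylic acid or a longer chain, would move the number beyond the scatter.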